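Methyl to Methoxy: Expecting the Next Measurement

The source may hold more compounds than are shown below. What is called first, only, known or untested is meant among the compounds shown, and "the series" means these compounds.

In an ADME assay on HCT-116 cells (Homo sapiens) for antiproliferative activity (a lower number here means a stronger inhibitor, a higher number a weaker inhibitor), compound 1 `COc1ccc(C(N)=O)cc1/C=C/c1ccc(C)cc1` gives 48000 nM. Compound 2 `COc1ccc(/C=C/c2cc(C(N)=O)ccc2OC)cc1` gives 19000 nM in this assay; it differs from compound 1 by methoxy in place of methyl on an aromatic carbon, which made a 2.5-fold lower number from compound 1 to compound 2 (0.40 log units; beyond the scatter). Compound 3 `COc1ccc(C(N)=O)cc1/C=C/c1ccccc1C` gives 11000 nM in this assay; the difference between the cores of compound 1 and compound 3 is not broken down here. Compound 4 `COc1ccccc1/C=C/c1cc(C(N)=O)ccc1OC` has not yet been measured. It differs from compound 3 by methoxy in place of methyl on an aromatic carbon, the same kind of change as before, though here the place is ortho to a large group where before it was para to a large group. The earlier step, a 2.5-fold lower number from compound 1 to compound 2 (0.40 log units; beyond the scatter), suggests a step of broadly similar size here, with some caution since the surroundings differ. The expected step is a 2.0-fold lower number from compound 3 to compound 4 (0.30 log units; within the scatter). Compound 4 is therefore expected to give 5500 nM, roughly between 2000 nM and 15000 nM.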

Compound 4, half-maximal inhibitory concentration: > 50000 nM
Compound 4 gave a limit, no number; the forecaster's own chance of this, stated with the estimate: 5%; at least 9.0-fold (0.95 log units) between middle value and limit.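

The change gave an at least 4.5-fold higher number from compound 3 to compound 4 (0.65 log units; beyond the scatter), so the earlier step did not carry over from one core to the other: the same change on two cores in this assay, a 2.5-fold lower number (0.40 log units; beyond the scatter) from compound 1 to compound 2 and an at least 4.5-fold higher number (0.65 log units; beyond the scatter) from compound 3 to compound 4, at least 11-fold (1.06 log units) apart, beyond the scatter of two such steps
In this assay compound 4 gives > 50000 nM, which is a limit of the assay and not a number.
Swapping methyl for methoxy therefore cannot be assumed to act the same way across this series, but two pairs do not show why the steps differ, and the full size of the new step remains unknown.

Going by these compounds, it remains open how an amine in place of the methyl, ortho to a large group, would compare. On these data alone, it is also open which of the two steps a third core would follow.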